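This account rests on a few compounds, and the source may have more. Where it says the series, first, only, none or still open, it means among the compounds named here.

Working notes on the series. The shared core is that of compound 2 `COc1cc2ncnc(Nc3ccc(F)c(Cl)c3)c2cc1OCCCSc1nc2ccccc2o1`; compound 1 `COc1cc2ncnc(Nc3ccc(F)c(Cl)c3)c2cc1OCCCSc1nc2ccccc2s1` and compound 3 `COc1cc2ncnc(Nc3ccc(OC(F)(F)F)cc3)c2cc1OCCCSc1nc2ccccc2o1` vary from it at one place each. In a functional assay on MCF7 cells (Homo sapiens) for cytotoxicity, read by MTT assay, with a stated time of 24 h (on this read-out lower numbers stand for stronger inhibition and higher numbers for weaker inhibition), compound 1 gives 5370 nM, compound 2 gives 4050 nM and compound 3 gives 9080 nM. On these three numbers compound 2 holds the lowest value, but its separation from compound 1 is within the scatter, so no order between those two is claimed; only compound 3 stands apart. a 1.3-fold lower number from compound 1 to compound 2 (0.12 log units; within the scatter). a 2.2-fold higher number from compound 2 to compound 3 (0.35 log units; beyond the scatter).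

Compound 4 `CCCCc1nc(Cl)c(C=O)n1CCCOc1cc2c(Nc3ccc(F)c(Cl)c3)ncnc2cc1OC` awaits measurement. It differs from compound 2 by 2-butyl-4-chloro-5-formyl-1H-imidazol-1-yl in place of (1,3-benzoxazol-2-yl)sulfanyl on a saturated chain carbon, three bonds along the chain from an oxygen on an aromatic ring. Neither measured step touches this change: the step from compound 1 to compound 2 exchanges 1,3-benzothiazol-2-yl for 1,3-benzoxazol-2-yl on the sulfur, and the step from compound 2 to compound 3 exchanges the aryl group on the nitrogen. One was within the scatter, the other modest, and the three compounds together span a narrow band in this assay. For the measured compounds named here, there is no precedent here for replacing the whole group at the end of the chain, so the expectation rests only on that narrow spread. The step of a 1.2-fold higher number from compound 2 to compound 4 (0.09 log units; within the scatter) is therefore expected to be small, in either direction, with a wide range kept. Compound 4 is estimated at 5000 nM, between 1500 nM and 16000 nM.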

Compound 4, half-maximal inhibitory concentration: 5020 nM
Beside the measured number, compound 4's estimate is 1.0-fold (0.00 log units) below it; low and high end bracket the measured number.
By their numbers in this assay, from the lowest: compounds 2, 4, 1 and 3 (each within the scatter of the next, the first and the last beyond it).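

In this assay, the whole group at the end of the chain can be exchanged with no separation in the numbers: a 1.2-fold higher number from compound 2 to compound 4 (0.09 log units; within the scatter), and a 1.1-fold lower number from compound 1 to compound 4 (0.03 log units; within the scatter). The earlier step varied only the ring system on the sulfur, whereas compound 4 has no sulfur and no six-membered aromatic ring in this group, carrying instead 2-butyl-4-chloro-5-formyl-1H-imidazol-1-yl on the same saturated chain carbon, so this place accepts a group of quite different make-up without a step beyond the scatter in this assay. Nothing at hand bears on the reason for this result.

From the compounds shown here alone, it remains open whether any group at the end of this chain separates from these compounds in this assay, for instance a simple amine such as piperidine, a carboxylic acid or a plain longer alkyl chain. For the compounds shown here, it is also open whether 4-(trifluoromethoxy)phenyl on the nitrogen, which gave the only step beyond the scatter, would give a similar step with 2-butyl-4-chloro-5-formyl-1H-imidazol-1-yl at the end of the chain.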